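The compounds below may be only part of what the source reports. "The series", "measured", "known", "first", "only" and "open" are said of these compounds alone.

Measured compounds:
- compound 1, `CC(C)(C)OC(=O)N1CCN(c2nc(=O)c3cc([N+](=O)[O-])cc([N+](=O)[O-])c3s2)CC1`: "not determined" (no result reported) in an ADME assay on Vero cells (Chlorocebus sabaeus) for cytotoxicity, read by MTT assay, with a stated time of 72 h; on this read-out higher numbers stand for weaker inhibition and lower numbers for stronger inhibition
- compound 2, `O=c1nc(NC2CC2)sc2c([N+](=O)[O-])cc(C(F)(F)F)cc12`: > 100000 nM in this assay

Compound 1 stands without a number in this assay; its entry reads as no result reported. Compound 2 sits at a limit of this assay rather than at a number, at > 100000 nM; the limit of > 100000 nM in this assay, at which 1 of the 2 values shown sits, covers one of the two entries shown. Within the data shown here, no pair of measured compounds differs in a single place, so no measured step can be drawn.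

Compound 3, `CC(C)(C)OC(=O)N1CCN(c2nc(=O)c3cc(C(F)(F)F)cc([N+](=O)[O-])c3s2)CC1`, is not yet measured. It differs from compound 1 by trifluoromethyl in place of nitro on an aromatic carbon. The same pairing of trifluoromethyl and nitro on the shared core is carried by compound 2, whose entry is a limit. The step from compound 1 to compound 3 cannot be sized, and in this assay nothing beyond the scatter is expected from it.

Compound 3 is expected at 100000 nM, within 30000 nM to 300000 nM, and most likely reported only as a limit.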

Compound 3, half-maximal inhibitory concentration: > 100000 nM
Compound 3: only a limit was reported; the forecaster's own chance of this, stated with the estimate: 70%; the middle value lies on the limit itself.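

No step can be read from compound 1 to compound 3 in this assay: compound 1 carries no number, and compound 3 carries only a limit. Left open is what number any of these compounds would give, and what trifluoromethyl in place of nitro does to it, with the series resting on: the limit of > 100000 nM in this assay, at which 2 of the 3 values shown sit.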